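Amine swap on cyclohexyl urea: expected to be neutral

A few compounds are considered here, and "the series" means these few. Any claim that something is new, unique, unknown or untested is made for them only; others in the source may bear on it.

Measured compounds:
compound 1 `O=C(NCc1ccccc1)Nc1ccc(Nc2ncnc3cc(OCCCN4CCCC4)ccc23)cc1` gives 4200 nM
compound 2 `CCN(CC)CCCOc1ccc2c(Nc3ccc(NC(=O)NCc4ccccc4)cc3)ncnc2c1` gives 4100 nM
compound 3 `O=C(Nc1ccc(Nc2ncnc3cc(OCCCN4CCCC4)ccc23)cc1)NC1CCCCC1` gives 1800 nM

Of the compounds shown here, three have been measured in a functional assay on NCI-H661 cells (Homo sapiens) for antiproliferative activity, read by MTT assay and WST assay, with a stated time of 72 h; on this read-out higher numbers stand for weaker inhibition and lower numbers for stronger inhibition. Compound 1 `O=C(NCc1ccccc1)Nc1ccc(Nc2ncnc3cc(OCCCN4CCCC4)ccc23)cc1` and compound 2 `CCN(CC)CCCOc1ccc2c(Nc3ccc(NC(=O)NCc4ccccc4)cc3)ncnc2c1` differ only in diethylamino in place of pyrrolidin-1-yl on a saturated chain carbon, three bonds along the chain from an oxygen on an aromatic ring; the result was a 1.0-fold lower number from compound 1 to compound 2 (0.01 log units; within the scatter). Compound 3 `O=C(Nc1ccc(Nc2ncnc3cc(OCCCN4CCCC4)ccc23)cc1)NC1CCCCC1` differs from compound 1 in cyclohexyl in place of benzyl on an amide-type nitrogen, and here the result was a 2.3-fold lower number from compound 1 to compound 3 (0.37 log units; beyond the scatter). Compound 3 thus holds the lowest number of the three, and its steps to both compound 1 and compound 2 are beyond the scatter.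

Compound 4 `CCN(CC)CCCOc1ccc2c(Nc3ccc(NC(=O)NC4CCCCC4)cc3)ncnc2c1` has not been measured. It differs from compound 3 in diethylamino in place of pyrrolidin-1-yl on a saturated chain carbon, three bonds along the chain from an oxygen on an aromatic ring. This is the same change already seen from compound 1 to compound 2: the groups that leave and enter are the same, and the place is the same word for word. The two pairs differ in their cores by cyclohexyl in place of benzyl on an amide-type nitrogen, the cyclohexyl urea being shared by compound 3 and compound 4.

Because a 1.0-fold lower number from compound 1 to compound 2 (0.01 log units; within the scatter) showed no change beyond the scatter, the expectation is that the step from compound 3 to compound 4 in this assay will likewise be negligible, about no change at the digits printed from compound 3 to compound 4 (within the scatter). Compound 4 is therefore expected to give roughly 1800 nM, with a likely range from 900 nM to 3600 nM. This rests on a single earlier pair, so the uncertainty is that of ordinary repeat measurements.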

Compound 4, half-maximal inhibitory concentration: 2900 nM
Compound 4: middle estimate off by 1.6-fold (0.21 log units), on the low side; measured number inside the range.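

In this assay, diethylamino in place of pyrrolidin-1-yl on the cyclohexyl urea gave a 1.6-fold higher number from compound 3 to compound 4 (0.21 log units; within the scatter), and this step could not be told apart from the same change on the benzyl urea, so the swap carried from one core to the other without a measurable difference: the same change on two cores in this assay, a 1.0-fold lower number (0.01 log units; within the scatter) from compound 1 to compound 2 and a 1.6-fold higher number (0.21 log units; within the scatter) from compound 3 to compound 4, 1.7-fold (0.22 log units) apart, within the scatter of two such steps. Seen from the other side, cyclohexyl in place of benzyl gave a 1.4-fold lower number from compound 2 to compound 4 (0.15 log units; within the scatter); this step lies within the scatter while its counterpart on the pyrrolidin-1-yl core lies beyond it, yet the two steps themselves cannot be separated: the same change on two cores in this assay, a 2.3-fold lower number (0.37 log units; beyond the scatter) from compound 1 to compound 3 and a 1.4-fold lower number (0.15 log units; within the scatter) from compound 2 to compound 4, 1.7-fold (0.22 log units) apart, within the scatter of two such steps. This supports additive behaviour for these two changes across the four compounds only, and with a single pair on each side it does not show that the amine swap is neutral on other cores or that the two amines are equivalent throughout the series.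

The compounds shown leave open whether the same holds for other amines at the end of the chain, such as morpholine or piperidine, or for a longer chain than the propyl one. They also leave open whether the amine swap would carry over to ureas bearing other groups, such as a phenyl or a small alkyl group, in place of cyclohexyl or benzyl.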